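The compounds below may be only part of what the source reports. "The series", "measured", "known", "first", "only" and "open" are said of these compounds alone.

The measured compounds are these. Compound 1 `O=C(O)Cc1sc(C(c2ccccc2)c2ccccc2)nc1-c1ccccc1` gives 370 nM in an in vitro functional assay on HEK285-7 cells for antagonist activity at prostaglandin D2 receptor 2 (Homo sapiens), read by BRET and beta-arrestin recruitment; on this read-out higher numbers stand for weaker inhibition and lower numbers for stronger inhibition. Compound 3 `O=C(O)Cc1sc(C(c2ccc(F)cc2)c2ccc(F)cc2)nc1-c1ccoc1` gives 130 nM in this assay. Compound 2 `CCC(c1ccccc1)c1nc(-c2ccc(Cl)cc2)c(CC(=O)O)s1` reaches only a limit of the assay, > 100000 nM in this assay, which is the limit of > 100000 nM in this assay, at which 1 of the 3 values shown sits.

Among the two numbers that are not limits, compound 1 stands at the higher one: compound 3 gives a lower number, and the gap between the two lies beyond the usual scatter of repeated measurements. Compound 3 differs from compound 1 in more than one place, so the two values show only where each stands, not what any single change does.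

Compound 4 `O=C(O)Cc1sc(C(c2ccccc2)c2ccccc2)nc1-c1ccc(F)cc1` has not yet been measured. It differs from compound 1 by fluoro in place of hydrogen on an aromatic carbon. Within the data shown here, no pair among the measured compounds differs in one place only, so nothing measured here tells what this change does on its own. The step of a 1.2-fold lower number from compound 1 to compound 4 (0.09 log units; within the scatter) is expected to be small, in either direction, and not beyond the scatter. Compound 4 is therefore estimated to give 300 nM in this assay, with a range from 120 nM to 800 nM.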

Compound 4, half-maximal inhibitory concentration: 77 nM
Compound 4: middle estimate off by 3.9-fold (0.59 log units), on the high side; measured number outside the range, below it.
By their numbers in this assay, from the lowest: compounds 4 and 3 (each within the scatter of the next); then compound 1. At a limit, above all of these: compound 2.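

In this assay, the move from phenyl to 4-fluorophenyl comes with a 4.8-fold lower number from compound 1 to compound 4 (0.68 log units; beyond the scatter), so this ring place, para to a large group, responds to a single fluoro in place of hydrogen by more than the usual scatter of repeated measurements. Among these compounds, this is the first pair that differs in one place only, and so the first reading of what one change does on its own, whereas compound 1 and compound 3 could show only where each stands. Nothing measured in this series bears on why the fluoro has this effect.

Among the compounds shown here, the single step leaves open whether other groups at this same place, such as methoxy, trifluoromethyl or an amine, would move the number in the same direction or by a similar amount. It also leaves open whether fluoro on either of the other two phenyl rings of compound 1 would give a step of this size, since one pair cannot show how far the result extends beyond this one ring.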